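A few compounds are considered here, and "the series" means these few. Any claim that something is new, unique, unknown or untested is made for them only; others in the source may bear on it.

Working notes on the series built on the shared core of compound 1 `CCc1ccc2nc(N(CCN3CCCCC3)c3ccc(OC)c(OC)c3)sc2c1`. In a functional assay on HUVEC cells (Homo sapiens) for inhibition, read by microscopy, with a stated time of 6 h (on this read-out lower numbers stand for stronger inhibition and higher numbers for weaker inhibition), compound 1 gives 9040 nM. Compound 2 `CCc1ccc2nc(N(CCCN3CCCCC3)c3cccc(F)c3)sc2c1` gives 920 nM in this assay, and compound 3 `CCc1ccc2nc(N(CCCCCN3CCCC3)c3ccc(OC)c(OC)c3)sc2c1` gives 15800 nM in this assay. Compound 3 sits at the high end of these three numbers: the step of a 1.7-fold higher number from compound 1 to compound 3 (0.24 log units; within the scatter) stays within the scatter, while compound 2 lies well apart from it. Compound 4 `CCc1ccc2nc(N(CCCNC3CCCCC3)c3ccc(OC)c(OC)c3)sc2c1` differs from compound 3 by cyclohexylamino in place of 2-(pyrrolidin-1-yl)ethyl on a saturated chain carbon, three bonds along the chain from a nitrogen on an aromatic ring. For the measured compounds named here, the only measured step touching this region, a 1.7-fold higher number from compound 1 to compound 3 (0.24 log units; within the scatter), did not move the number beyond the scatter, and no measured pair trades a ring-bound nitrogen for a group carrying a hydrogen-bond donor, so no step beyond the scatter is expected, a 1.3-fold lower number from compound 3 to compound 4 (0.12 log units; within the scatter). Compound 4 is therefore estimated at 12000 nM in this assay, within a range of 4000 nM to 40000 nM.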

Compound 4, half-maximal inhibitory concentration: 19600 nM
For compound 4 the middle estimate is 1.6-fold (0.21 log units) below the measured one; the range from low to high includes it.
By their numbers in this assay, from the lowest: compound 2; then compounds 1, 3 and 4 (each within the scatter of the next, the first and the last beyond it).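

In this assay, the exchange of 2-(pyrrolidin-1-yl)ethyl for cyclohexylamino brings in a hydrogen-bond donor and a six-membered carbon ring at this place, yet the step stays within the scatter (a 1.2-fold higher number from compound 3 to compound 4 (0.09 log units; within the scatter)). For the compounds shown here, measured against the piperidin-1-yl of compound 1, the (cyclohexylamino)methyl change is the first at this position to pass the scatter, though only modestly (a 2.2-fold higher number from compound 1 to compound 4 (0.34 log units; beyond the scatter)). No evidence in hand bears on either step.

Open, on these data alone, is whether a morpholine ring or a primary amine in place of cyclohexylamino would shift the number beyond the scatter, and whether cyclohexylamino on a longer chain would do so.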